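The source may hold more compounds than are shown below. What is called first, only, known or untested is meant among the compounds shown, and "the series" means these compounds.

Measured compounds:
compound 1 `COc1ccccc1Oc1ccc2c(NCCCNCc3ccco3)ccnc2c1` — 6500 nM
compound 2 `COc1cccc(CNCCCNc2ccnc3cc(-c4ccc(C(F)(F)F)cc4)ccc23)c1O` — 2210 nM

The two measured compounds were tested in an ADME assay on HepG2 cells (Homo sapiens) for cytotoxicity, read by luminescence, CellTiter-Glo and ATP content, with a stated time of 72 h; a higher number here means that more compound is needed for the effect, a lower number that less compound is needed. Compound 1 gives 6500 nM, the higher of the two numbers. Compound 2 gives 2210 nM, a lower number, and the gap between the two lies beyond the usual scatter of this assay; since the two compounds differ in more than one place, the pair tells nothing about any single change.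

Compound 3 `c1ccc(Cc2ccc3c(NCCCNCc4ccco4)ccnc3c2)cc1` has not yet been measured in this assay. It differs from compound 1 in one place: benzyl in place of 2-methoxyphenoxy on an aromatic carbon. Among the measured compounds shown here, no measured pair shows this exchange, so the data give no step to lean on. The step from compound 1 to compound 3 is expected to be small, probably not beyond the scatter, in either direction. For compound 3 the estimate is 5000 nM, with a range from 1500 nM to 16000 nM; the expected step is a 1.3-fold lower number from compound 1 to compound 3 (0.11 log units; within the scatter).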

Compound 3, half-maximal effective concentration: 16000 nM
Estimate against measurement, compound 3: 3.2-fold (0.51 log units) below, within the range that was stated.
By their numbers in this assay, from the lowest: compound 2; then compound 1; then compound 3.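

In this assay, the exchange at this aromatic carbon is not silent: benzyl in place of 2-methoxyphenoxy gives a 2.5-fold higher number from compound 1 to compound 3 (0.39 log units; beyond the scatter), a modest change but one that shows this position on the shared core bears on the number. The earlier pair could not show this, as those two compounds differ in more than one place. The leaving group has two hydrogen-bond acceptors and the entering group none, while both carry a six-membered aromatic ring of carbon only, and nothing measured here gives a cause for the step.

The compounds shown leave open whether the step belongs to the linking oxygen or to the methoxy group, which a plain phenoxy or a 2-methoxybenzyl group would separate. They also leave open whether an amine or a carboxylic acid on this carbon would move the number in the same direction.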